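Chloro on the Sulfonyl Phenyl Across Two Cores

The compounds below may be only part of what the source reports. "The series", "measured", "known", "first", "only" and "open" are said of these compounds alone.

Measured in a functional assay on HeLa cells (Homo sapiens) for inhibition, read by MTT assay, with a stated time of 48 h; on this read-out lower numbers stand for stronger inhibition and higher numbers for weaker inhibition:
compound 1, `COc1ccc(-n2cc(NC(=O)c3cccc(NS(=O)(=O)c4ccccc4)c3)cn2)cc1`: 42200 nM
compound 2, `COc1ccc(-n2cc(NC(=O)c3cccc(NS(=O)(=O)c4ccc(Cl)cc4)c3)cn2)cc1`: 19700 nM
compound 3, `Cc1ccc(-n2cc(NC(=O)c3ccc(NS(=O)(=O)c4ccccc4)cc3)cn2)cc1`: 27900 nM

Compound 2 differs from compound 1 by chloro in place of hydrogen on an aromatic carbon, and that change gave a 2.1-fold lower number from compound 1 to compound 2 (0.33 log units; beyond the scatter). Compound 3 has another core; the difference between the two cores is not broken down here. Its value in this assay sits within the scatter of both compound 1 and compound 2, so no order among the three is claimed. Compound 4, `Cc1ccc(-n2cc(NC(=O)c3ccc(NS(=O)(=O)c4ccc(Cl)cc4)cc3)cn2)cc1`, differs from compound 3 by chloro in place of hydrogen on an aromatic carbon, the same change as before, at the same kind of place. The step is expected to be a 2.0-fold lower number from compound 3 to compound 4 (0.30 log units; within the scatter), resting on a 2.1-fold lower number from compound 1 to compound 2 (0.33 log units; beyond the scatter) in the other core. Compound 4 is therefore expected to give 14000 nM in this assay. Compound 4 is estimated to fall between 7000 nM and 28000 nM.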

Compound 4, half-maximal inhibitory concentration: 8010 nM
Estimate against measurement, compound 4: 1.7-fold (0.24 log units) above, and the stated range covers the measured number.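

In this assay, chloro in place of hydrogen on the phenylsulfonyl group again went with a lower number, this time a 3.5-fold lower number from compound 3 to compound 4 (0.54 log units; beyond the scatter) and so the change carried in the same direction from the core of compound 1 to the core of compound 3. The two steps do not differ in size by more than repeated measurement allows: the same change on two cores in this assay, a 2.1-fold lower number (0.33 log units; beyond the scatter) from compound 1 to compound 2 and a 3.5-fold lower number (0.54 log units; beyond the scatter) from compound 3 to compound 4, 1.6-fold (0.21 log units) apart, within the scatter of two such steps. This rests on a single pair per core in one cell assay, so it does not show that the change would carry to any further core, nor why it lowers the number.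

The compounds shown leave open whether another group at that place, such as an amine or a carboxylic acid, would act as chloro does. They also do not break down the difference between the two cores.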